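Swapping bromo for methylsulfanyl on the shared core

A few compounds are considered here, and "the series" means these few. Any claim that something is new, unique, unknown or untested is made for them only; others in the source may bear on it.

Of the compounds shown here, three with a shared core have been measured in an assay on isolated protein for inhibition of prostaglandin E2 receptor EP1 subtype (Homo sapiens); on this read-out lower numbers stand for stronger inhibition and higher numbers for weaker inhibition. Compound 1 `CSc1ccc(OCc2ccc(F)cc2F)c(C2=C(c3cccc(C(=O)O)c3)CCC2)c1` gives 15.9 nM, compound 2 `O=C(O)c1cccc(C2=C(c3cc(Cl)ccc3OCc3ccccc3)CCC2)c1` gives 5.01 nM, and compound 3 `O=C(O)c1cccc(C2=C(c3cc(Br)ccc3OCc3ccccc3)CCC2)c1` gives 12.6 nM. Compound 3 stands second highest of the three numbers; its nearest neighbour is compound 1, within the scatter, while compound 2 lies furthest away, beyond it. Going by the values given here, the only single-point step among them, a 2.5-fold higher number from compound 2 to compound 3 (0.40 log units; beyond the scatter), was modest. Compound 4 `CSc1ccc(OCc2ccccc2)c(C2=C(c3cccc(C(=O)O)c3)CCC2)c1` differs from compound 3 by methylsulfanyl in place of bromo on an aromatic carbon. Among the compounds with values here, no measured step covers this exchange directly, but compound 1 also carries methylsulfanyl and gives 15.9 nM, so a step near the scatter, a 1.1-fold lower number from compound 3 to compound 4 (0.02 log units; within the scatter), is expected. Compound 4 is estimated at 12 nM, ranging from 5 nM to 30 nM.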

Compound 4, half-maximal inhibitory concentration: 63.1 nM
The estimate for compound 4 lay 5.3-fold (0.72 log units) below the measured number; the measured number lies above the stated range.
By their numbers in this assay, from the lowest: compound 2; then compounds 3 and 1 (each within the scatter of the next); then compound 4.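

At the place para to the benzyloxy group, methylsulfanyl gives a higher number than either halogen in this assay: a 5.0-fold higher number from compound 3 to compound 4 (0.70 log units; beyond the scatter), and a 13-fold higher number from compound 2 to compound 4 (1.10 log units; beyond the scatter). With methylsulfanyl held fixed, phenyl in place of 2,4-difluorophenyl also raises the number, a 4.0-fold higher number from compound 1 to compound 4 (0.60 log units; beyond the scatter), so the value of compound 1 does not carry over to the phenyl compounds.

No measurement at hand explains these steps. As far as these compounds go, it remains open how methoxy or nitrile would fare at this place, and whether the 2,4-difluorophenyl exchange gives a similar step alongside chloro or bromo.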